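This account rests on a few compounds, and the source may have more. Where it says the series, first, only, none or still open, it means among the compounds named here.

Compound 1 `CCN1CCN(CCCn2cnc3c(N4CCN(C(=O)C5CCCC5)CC4)nc(N)nc32)CC1`: > 30000 nM in an assay on HEK293 cells for antagonist activity at Toll-like receptor 9 (Homo sapiens), read by spectrophotometry (a higher number here means a weaker inhibitor, a lower number a stronger inhibitor), a limit of the assay.
Compound 2 `CCN1CCN(CCCn2cnc3c(N4CCN(C5CCCC5)CC4)nc(NCc4ccc(OC)cc4)nc32)CC1`: 120 nM.
Compound 3 `CCN1CCN(CCCn2cnc3c(N4CCN(C5CCCC5)CC4)nc(NCc4ccc(N(CC)CC)cc4)nc32)CC1`: 150 nM.

Among the compounds with values here, compound 3 holds the highest of the two numbers in this assay, with compound 2 nearest, and the only measured step, a 1.3-fold higher number from compound 2 to compound 3 (0.10 log units; within the scatter), is within the scatter, so the two cannot be ranked. Compound 1 sits at a limit (the limit of > 30000 nM in this assay, at which 1 of the 3 values shown sits). It carries the cyclopentylcarbonyl that compound 4 also carries, but it differs from compounds 2 and 3 at a second place as well, so its limit cannot be traced to either difference alone.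

Compound 4 `CCN1CCN(CCCn2cnc3c(N4CCN(C(=O)C5CCCC5)CC4)nc(NCc4ccc(N(CC)CC)cc4)nc32)CC1` differs from compound 3 by cyclopentylcarbonyl in place of cyclopentyl on an amine nitrogen in a ring. Within the data shown here, no measured step covers this exchange; the one step measured, a 1.3-fold higher number from compound 2 to compound 3 (0.10 log units; within the scatter), concerns the substituent on the aromatic carbon and says nothing about the ring nitrogen. Among the measured compounds shown here, the only measured compound that bears the cyclopentylcarbonyl gives a limit rather than a number, and the two compounds bearing the cyclopentyl give the two numbers near each other. On that basis a higher number is expected for compound 4, beyond the scatter, though the size is uncertain and a limit is possible. Compound 4 is estimated at 3000 nM, within 400 nM to 30000 nM, an expected step of a 20-fold higher number from compound 3 to compound 4 (1.30 log units; beyond the scatter).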

Compound 4, half-maximal inhibitory concentration: 8800 nM
For compound 4 the middle estimate is 2.9-fold (0.47 log units) below the measured one, within the range that was stated.
By their numbers in this assay, from the lowest: compounds 2 and 3 (each within the scatter of the next); then compound 4. At a limit, above all of these: compound 1.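

In this assay, within the data shown here, the exchange of cyclopentyl for cyclopentylcarbonyl on the amine nitrogen in the ring now has a measured size, a 59-fold higher number from compound 3 to compound 4 (1.77 log units; beyond the scatter), whereas the earlier compounds offered no pair that differed at this place alone. At the other place that changes, 4-(diethylamino)benzyl in place of hydrogen on a nitrogen on an aromatic ring gives an at least 3.4-fold lower number from compound 1 to compound 4 (0.53 log units; beyond the scatter), so this substituent still goes with a lower number when the cyclopentylcarbonyl is present, although compound 4 remains far from compounds 2 and 3. Compound 1 stands at a limit, so that step fixes only a bound on the size of the change: the limit of > 30000 nM in this assay, at which 1 of the 4 values shown sits.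

On these data alone, it remains open whether the large step belongs to the carbonyl on the ring nitrogen in particular or would also appear with other groups at that nitrogen, such as a methylsulfonyl, an acetyl or a plain methyl. As far as these compounds go, it is also open how much the 4-(diethylamino)benzyl contributes when cyclopentyl sits on the ring nitrogen, and whether a 4-methoxybenzyl would behave the same way alongside the cyclopentylcarbonyl.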